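Taking the sulfonylamino group out of compound 2

The source may report more compounds than this note shows. Statements on the series, on what has been measured and on what is new or still open speak of the compounds shown alone.

Values in a functional assay for inhibition, with Homo sapiens as the target; a lower number here means a stronger inhibitor, a higher number a weaker inhibitor:
compound 1 `O=C(NCc1ccccc1)N[C@@H](CNC(=O)c1cc2cc(CCC3CCNCC3)sc2s1)C(=O)O`: 76 nM
compound 2 `O=C(NC[C@H](NS(=O)(=O)c1ccccc1)C(=O)O)c1cc2sc(CCC3CCNCC3)cc2s1`: 8 nM

Of these two, compound 2 holds the lower number in this assay, and compound 1 lies above it by more than the usual scatter. Compound 3 `O=C(O)CCNC(=O)c1cc2sc(CCC3CCNCC3)cc2s1` has not yet been measured. The change leading to it is hydrogen in place of (phenylsulfonyl)amino on a saturated chain carbon bound to a carbonyl carbon and a saturated chain carbon.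

Within the data shown here, no measured compound has hydrogen at that place, so the size of the step remains uncertain. A weakening beyond the scatter is expected in this assay, meaning a higher number. The reference points are compound 2 at 8 nM and compound 1 at 76 nM. The expected change is a 19-fold higher number from compound 2 to compound 3 (1.27 log units; beyond the scatter). For compound 3 the estimated value is 150 nM, with an expected range of 40 nM to 600 nM.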

Compound 3, half-maximal inhibitory concentration: 500 nM
Beside the measured number, compound 3's estimate is 3.3-fold (0.52 log units) below it, within the range that was stated.
By their numbers in this assay, from the lowest: compound 2; then compound 1; then compound 3.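

Hydrogen in place of (phenylsulfonyl)amino on this saturated chain carbon bound to a carbonyl carbon and a saturated chain carbon is costly in this assay: the change gives a 63-fold higher number from compound 2 to compound 3 (1.80 log units; beyond the scatter), so much of the potency of compound 2 depends on what sits at this place. Without that group, compound 3 still gives 500 nM, so the shared core with its carboxylic acid retains inhibition on its own. Nothing available explains the size of this step.

Still open, as far as these compounds go, is how much of the loss belongs to the six-membered aromatic ring and how much to the sulfonylamino part. A plain amine or a methylsulfonylamino group at this place would separate the two contributions.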